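Dropping Two Fluorines from the Amide Aryl Ring

This account rests on a few compounds, and the source may have more. Where it says the series, first, only, none or still open, it means among the compounds named here.

Compound 1 `O=C(Nc1cc(-c2ccccc2)nn1-c1ccccc1)c1ccc(F)c(F)c1` gives 20 nM in an assay on isolated protein with metabotropic glutamate receptor 5 (Rattus norvegicus) as the target (a lower number here means that less compound is needed, a higher number that more compound is needed for the effect), and of the two measured numbers it sits at the end needing the least compound, though only by the step of a 2.0-fold higher number from compound 1 to compound 2 (0.30 log units; within the scatter). Compound 2 `Cc1ccc(C(=O)Nc2cc(-c3ccccc3)nn2-c2ccccc2)cc1` gives 40 nM in this assay. Compound 3 `O=C(Nc1cc(-c2ccccc2)nn1-c1ccccc1)c1ccccc1` differs from compound 1 by phenyl in place of 3,4-difluorophenyl on a carbonyl carbon. Within the data shown here, the one comparable step, exchanging the same 3,4-difluorophenyl for another ring, stayed within the scatter, so the step of a 2.0-fold higher number from compound 1 to compound 3 (0.30 log units; within the scatter) is also expected to stay within the scatter. Compound 3 is estimated at 40 nM, ranging from 12 nM to 150 nM.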

Compound 3, half-maximal effective concentration: 300 nM
Beside the measured number, compound 3's estimate is 7.5-fold (0.88 log units) below it; the measured number lies above the stated range.
By their numbers in this assay, from the lowest: compounds 1 and 2 (each within the scatter of the next); then compound 3.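

In this assay, the ring on the carbonyl carbon is clearly not indifferent to what it carries: plain phenyl gives up much of the activity (a 15-fold higher number from compound 1 to compound 3 (1.18 log units; beyond the scatter)) and also falls behind the methyl-bearing ring (a 7.5-fold higher number from compound 2 to compound 3 (0.88 log units; beyond the scatter)). Among these compounds, a ring with either two fluorines or one methyl gives a low number, while the ring with neither gives the highest. Nothing measured here explains this difference. Still open, going by these compounds, is whether a single fluorine would be enough, and whether a chlorine, a methoxy group or an amine on this ring would also keep the number low.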